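A few compounds are considered here, and "the series" means these few. Any claim that something is new, unique, unknown or untested is made for them only; others in the source may bear on it.

Working notes on the series. In a toxicity assay on microsomes from liver (Homo sapiens) for metabolic stability, read by LC-MS, using NADPH, tested at 1 uM (on this read-out lower numbers stand for slow clearance and higher numbers for fast clearance), compound 1 `CCc1ncc(-c2nc(C(F)(F)F)sc2N2CCN(C(=O)Cn3nc(C)nc3C)[C@H](C)C2)cn1` gives 43 mL.min-1.g-1, and compound 2 `CCCc1ncc(-c2nc(C(F)(F)F)sc2N2CCN(C(=O)Cn3nc(C)nc3C)[C@H](C)C2)cn1` gives 80 mL.min-1.g-1. The step between them reads a 1.9-fold higher number from compound 1 to compound 2 (0.27 log units; within the scatter). Compound 3 `Cc1nc(C)n(CC(=O)N2CCN(c3sc(C(F)(F)F)nc3-c3cnc(C4CC4)nc3)C[C@H]2C)n1` gives < 10 mL.min-1.g-1, which is a limit of the assay and not a number.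

Compound 4 `Cc1nc(C)n(CC(=O)N2CCN(c3sc(C(F)(F)F)nc3-c3cnc(N4CCCC4)nc3)C[C@H]2C)n1` carries pyrrolidin-1-yl in place of cyclopropyl on an aromatic carbon between two ring nitrogen atoms (pyrrolidin-1-yl in place of cyclopropyl on an aromatic carbon).

Among the compounds with values here, two measured steps concern this same carbon: an at least 4.3-fold lower number from compound 1 to compound 3 (0.63 log units; beyond the scatter) and an at least 8.0-fold lower number from compound 2 to compound 3 (0.90 log units; beyond the scatter). Neither brings in pyrrolidin-1-yl, so they offer a guide to size only. In both, the group other than cyclopropyl carries the higher number. On that basis, a step of similar size is expected in this assay, upward from compound 3 and not certain to clear the limit. The expected step is an at least 2.5-fold higher number from compound 3 to compound 4 (0.39 log units; beyond the scatter). This leans on compound 1 at 43 mL.min-1.g-1 as the nearer reference. For compound 4 the estimated value is 25 mL.min-1.g-1, with an expected range of 10 mL.min-1.g-1 to 60 mL.min-1.g-1.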

Compound 4, intrinsic clearance in microsomes: 338 mL.min-1.g-1
For compound 4 the middle estimate is 14-fold (1.13 log units) below the measured one; measured number above the stated range.
By their numbers in this assay, from the lowest: compounds 1 and 2 (each within the scatter of the next); then compound 4. At a limit, below all of these: compound 3.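

In this assay, the aromatic carbon between two ring nitrogen atoms tolerates a much wider spread of values than the alkyl and cyclopropyl groups alone suggested, with an at least 33-fold higher number from compound 3 to compound 4 (1.52 log units; beyond the scatter). The value of compound 3 is a limit and not a number: the limit of < 10 mL.min-1.g-1 in this assay, at which 1 of the 4 values shown sits. Pyrrolidin-1-yl also stands beyond both open-chain groups, with a 4.2-fold higher number from compound 2 to compound 4 (0.63 log units; beyond the scatter) and a 7.9-fold higher number from compound 1 to compound 4 (0.90 log units; beyond the scatter), and since cyclopropyl and pyrrolidin-1-yl are both non-aromatic rings, a ring on this carbon does not by itself go with a low number.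

The compounds shown do not separate ring size from attachment through nitrogen. A cyclopentyl group on this carbon would keep the five-membered ring without the nitrogen, and azetidin-1-yl would keep the nitrogen with a smaller ring.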